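Cytotoxicity at the Limit: From Carbamate to Methoxy

A few compounds are considered here, and "the series" means these few. Any claim that something is new, unique, unknown or untested is made for them only; others in the source may bear on it.

In an ADME assay on PBMC cells (Homo sapiens) for cytotoxicity, read by trypan blue exclusion, with a stated time of 6 days (on this read-out lower numbers stand for higher toxicity in this test and higher numbers for lower toxicity in this test), three compounds have been measured:
compound 1 `CC(C)(C)OC(=O)NOc1nc(N)nc2c1ncn2[C@@H]1O[C@H](CO)[C@@H](O)[C@@]1(C)O` gives > 100000 nM, a limit of the assay and not a number.
compound 2 `C[C@@]1(O)[C@H](O)[C@@H](CO)O[C@H]1n1cnc2c(N)nc(N=[N+]=[N-])nc21` gives > 100000 nM, likewise a limit of the assay.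
compound 3 `COc1nc(ONC(=O)OCc2ccccc2)nc2c1ncn2[C@@H]1O[C@H](CO)[C@@H](O)[C@@]1(C)O` gives > 100000 nM, again a limit of the assay.

Compound 3 therefore stands where every measured compound stands: the limit of > 100000 nM in this assay, at which 3 of the 3 values shown sit. Among the measured compounds shown here, no step between measured compounds is available, as the three differ in more than one place. Compound 4 `COc1nc(OC)c2ncn([C@@H]3O[C@H](CO)[C@@H](O)[C@@]3(C)O)c2n1` differs from compound 3 in one place: methyl in place of (benzyloxycarbonyl)amino on an oxygen on an aromatic ring. Since all three measured values sit at the limit, the step expected is a number no higher from compound 3 to compound 4 (the limit leaves the size open), none beyond the scatter. Compound 4 is expected at 100000 nM, with a range from 50000 nM to 300000 nM.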

Compound 4, half-maximal cytotoxic concentration: > 100000 nM
Compound 4 ended at the assay's limit (the forecaster's own chance of this, stated with the estimate: 85%); the middle value lies on the limit itself.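

No step can be read from compound 3 to compound 4, whose values are both limits: the limit of > 100000 nM in this assay, at which 4 of the 4 values shown sit. The compounds shown leave open which change of structure, if any, would yield a readable number in this assay.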